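This account rests on a few compounds, and the source may have more. Where it says the series, first, only, none or still open, it means among the compounds named here.

Compound 1 `CCCc1cc(N)c2cc(NC(=O)/C=C/c3ccc(C(C)(C)C)cc3)ccc2n1` stands at the higher of the two numbers recorded in an assay on isolated protein for displacement of a labelled ligand from melanin-concentrating hormone receptor 1 (Homo sapiens); a lower number here means a stronger inhibitor, a higher number a weaker inhibitor: there compound 1 gives 22 nM. Among the measured compounds shown here, the only other measured compound, compound 2 `Nc1cc(C2CCCC2)nc2ccc(NC(=O)/C=C/c3ccc(C(F)(F)F)cc3)cc12`, differs from compound 1 in more than one place, and in this assay compound 2 gives 0.8 nM, a clearly lower number than that of compound 1. These two structures are not separated by a single change. For the measured compounds named here, nothing in their values isolates the effect of any one alteration, and no step between measured compounds is available to lean on.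

Compound 3 `CCCCc1ccc(/C=C/C(=O)Nc2ccc3nc(CCC)cc(N)c3c2)cc1` is built from the same atoms as compound 1, joined differently: butyl in place of tert-butyl on an aromatic carbon. The group that leaves and the group that enters agree in every count given. Going by the values given here, with no measured pair to calibrate such a swap, the expectation is a step of no more than modest size, and a small weakening is judged somewhat more likely than a gain, so the step from compound 1 to compound 3 is estimated at a 1.6-fold higher number from compound 1 to compound 3 (0.20 log units; within the scatter). For compound 3 in this assay the estimated value is 35 nM, with a range from 9 nM to 140 nM.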

Compound 3, half-maximal inhibitory concentration: 45 nM
The estimate for compound 3 lay 1.3-fold (0.11 log units) below the measured number; the measured number falls inside the stated range.
By their numbers in this assay, from the lowest: compound 2; then compound 1; then compound 3.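

In this assay, the replacement of tert-butyl by butyl gives a 2.0-fold higher number from compound 1 to compound 3 (0.31 log units; beyond the scatter). Among the compounds shown here, this is the first step between measured compounds that differ in one place, and so the first reading of this position on its own: the group leaving and the group entering match in every count given, yet their different joining alone shifts the number by a modest step, just past the usual scatter, with a higher number for the straight chain. No measured property of these compounds bears on this step, so the data describe its size and direction without accounting for them.

On these data alone, whether a shorter chain such as ethyl, a longer chain such as hexyl, or a group of another kind such as an amine or a carboxylic acid on this aromatic carbon would move the number further in either direction remains open. Also open, as far as these compounds go, is whether the same swap would give a step of similar size if the propyl group on the shared core were replaced by another group, such as cyclohexyl.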